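The source may hold more compounds than are shown below. What is called first, only, known or untested is meant among the compounds shown, and "the series" means these compounds.

Compound 1 `c1ccc(-c2nc[nH]n2)c(NCC2=NCCN2)c1` is measured in an in vitro functional assay on cells (Fibroblast) for agonist activity at Alpha-1A adrenergic receptor (Homo sapiens) (a higher number here means that more compound is needed for the effect, a lower number that less compound is needed), where it gives 0.794 nM, the lowest of the three numbers recorded. Compound 2 `CCn1ncnc1-c1ccccc1NCC1=NCCN1`, which carries an ethyl group on its five-membered ring, gives 1.26 nM, within the usual scatter of compound 1. Compound 3 `Cc1nc(-c2ccccc2NCC2=NCCN2)n(C)n1`, carrying two methyl groups on that ring, gives 1000 nM, a gap far beyond the scatter. Compound 4 `Cn1nccc1-c1ccccc1NCC1=NCCN1` has not yet been measured. It differs from compound 1 in one place: 1-methyl-1H-pyrazol-5-yl in place of 1H-1,2,4-triazol-3-yl on an aromatic carbon. Compound 2, bearing a single alkyl group on its five-membered ring, gives 1.26 nM and is the nearest guide here. The expected step is small and in no settled direction, a 2.5-fold higher number from compound 1 to compound 4 (0.40 log units; beyond the scatter). Compound 4 is therefore expected to give 2 nM, with a likely range from 0.5 nM to 10 nM.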

Compound 4, half-maximal effective concentration: 10 nM
Compound 4: middle estimate off by 5.0-fold (0.70 log units), on the low side; measured number inside the range.
By their numbers in this assay, from the lowest: compounds 1 and 2 (each within the scatter of the next); then compound 4; then compound 3.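

Replacing 1H-1,2,4-triazol-3-yl with 1-methyl-1H-pyrazol-5-yl on this aromatic carbon gives a 13-fold higher number from compound 1 to compound 4 (1.10 log units; beyond the scatter) in this assay, so the activity responds strongly to which five-membered ring sits here. The change removes the ring's hydrogen-bond donor, swaps a ring nitrogen for carbon and adds a methyl group, all in one step. Nothing available explains the size of this step.

Which of those three differences matters most remains open. So does how this position would respond to a ring carrying an amine or a carboxylic acid.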